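From Fluoro to Chloro: Expecting a Modest Lipophilicity Rise

The source may report more compounds than this note shows. Statements on the series, on what has been measured and on what is new or still open speak of the compounds shown alone.

Of the compounds shown here, three sharing one core have been measured in a physicochemical assay for lipophilicity; a higher number here means a more lipophilic compound, a lower number a more polar compound. Compound 1 `Cc1cc(=O)[nH]c2cc(NC(=O)c3ccc(F)cc3)ccc12` carries a fluoro group and gives 1.61. Compound 2 `Cc1cc(=O)[nH]c2cc(NC(=O)c3c(Br)cccc3Br)ccc12` gives 1.75, and compound 3 `Cc1cc(=O)[nH]c2cc(NC(=O)c3cccc4ccccc34)ccc12` gives 1.72. For the measured compounds named here, the value of compound 1 lies within the scatter of both other numbers, so the three measurements cannot be told apart with confidence, and no step between any two measured compounds is on record.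

Compound 4 `Cc1cc(=O)[nH]c2cc(NC(=O)c3ccc(Cl)cc3)ccc12` has not yet been measured. It differs from compound 1 in one place: chloro in place of fluoro on an aromatic carbon. In this assay this kind of change is expected to move the number upward, though only by a modest amount, since the three measured values already show how narrowly this set spreads even across quite different groups. The estimated step of a number 0.21 log units higher from compound 1 to compound 4 (within the scatter) expresses that expectation. Compound 4 is therefore expected to give 1.82, with a range from 1.6 to 2.1. This rests on compound 1, whose value is 1.61.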

Compound 4, partition coefficient: 1.69
Compound 4: middle estimate off by 0.13 log units, on the high side, and the stated range covers the measured number.
By their numbers in this assay, from the lowest: compounds 1, 4, 3 and 2 (each within the scatter of the next).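

For the compounds shown here, this is the first step on record in this set that changes one place only, and in this assay chloro in place of fluoro on an aromatic carbon, para to a large group, gives a number 0.08 log units higher from compound 1 to compound 4 (within the scatter). Going from 4-fluorophenyl to 4-chlorophenyl at this position therefore leaves the two compounds indistinguishable in this measurement, which the earlier compounds could not show because no two of them formed such a pair. Nothing measured here offers a reason for the size of this step.

Still open, from the compounds shown here alone, is whether a different group at this same place, such as an amine, a carboxylic acid or a methoxy group, would give a step beyond the scatter. Also open, going by these compounds, is whether the same exchange of fluoro for chloro would give a similar step elsewhere on this ring.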